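The compounds below may be only part of what the source reports. "The series", "measured", "known", "first", "only" and "open" are said of these compounds alone.

Of the compounds shown here, three sharing one core have been measured so far in an assay on isolated protein for inhibition of aldehyde dehydrogenase 1A1 (Homo sapiens), read by spectrophotometry, tested at 10 uM; a higher number here means more inhibition at the concentration tested (going by the name of the read-out), a lower number less inhibition. Compound 1 `O=C(C1CC1)N1CCN(Cc2nc3ccccc3n2Cc2ccccc2C(F)(F)F)CC1` gives 56.3%, compound 2 `O=C(C1CC1)N1CCN(Cc2nc3ccccc3n2Cc2cccc(F)c2)CC1` gives 27.2%, and compound 3 `O=C(C1CC1)N1CCN(Cc2nc3ccccc3n2Cc2ccccc2F)CC1` gives 40.7%. Compound 3 therefore stands second highest of the three: its nearest neighbour is compound 2, a number lower beyond the scatter, and its furthest is compound 1, a number higher beyond the scatter. The steps measured so far are a number 29.1 percentage points lower from compound 1 to compound 2 (beyond the scatter), a number 15.6 percentage points lower from compound 1 to compound 3 (beyond the scatter) and a number 13.5 percentage points higher from compound 2 to compound 3 (beyond the scatter).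

Compound 4 `O=C(C1CC1)N1CCN(Cc2nc3ccccc3n2Cc2ccc(Cl)cc2)CC1` differs from compound 3 in one place: 4-chlorophenyl in place of 2-fluorophenyl on a saturated chain carbon bound to an aromatic nitrogen. Among the compounds with values here, no measured pair carries the same change. Within the data shown here, the steps that bear on it are the two that alter the group on the saturated chain carbon bound to an aromatic nitrogen: the exchange of 3-fluorophenyl for 2-fluorophenyl, a number 13.5 percentage points higher from compound 2 to compound 3 (beyond the scatter), and the exchange of 2-(trifluoromethyl)phenyl for 3-fluorophenyl, a number 29.1 percentage points lower from compound 1 to compound 2 (beyond the scatter). Both are modest and both show that moving or altering the halogen-bearing phenyl shifts the read-out by more than the scatter, with compound 3 and compound 1 ahead of compound 2. A modest downward step is therefore expected for a number 10.7 percentage points lower from compound 3 to compound 4 (beyond the scatter). Compound 4 is estimated to give 30% in this assay, within a range from 10% to 52%.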

Compound 4, a percentage reported as inhibition, at one concentration (the size of the read-out at that concentration, not a potency): 56.6%
For compound 4 the middle estimate is 26.6 percentage points below the measured one, outside the stated range (above it).
By their numbers in this assay, from the lowest: compound 2; then compound 3; then compounds 1 and 4 (each within the scatter of the next).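

In this assay, the exchange of 2-fluorophenyl for 4-chlorophenyl on a saturated chain carbon bound to an aromatic nitrogen gives a number 15.9 percentage points higher from compound 3 to compound 4 (beyond the scatter), and the exchange of 3-fluorophenyl for 4-chlorophenyl gives a number 29.4 percentage points higher from compound 2 to compound 4 (beyond the scatter), so a ring carrying chlorine reaches a level that neither fluorinated ring reached. Set against the 2-(trifluoromethyl)phenyl group, the same group gives a number 0.3 percentage points higher from compound 1 to compound 4 (within the scatter), which shows that this level at this position does not depend on the trifluoromethyl group and is shared by two differently substituted rings, while 2-fluorophenyl and 4-chlorophenyl, which have the same count of heavy atoms, still stand apart beyond the scatter. Nothing on hand accounts for these differences.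

The change to 4-chlorophenyl swaps the halogen and its place on the ring in one step, so the compounds shown cannot tell which of the two carries the rise. They also leave open how an unsubstituted phenyl, a methoxyphenyl or an aminophenyl would read at this position, and how a carboxylic acid on the ring would read there.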